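From 3,5-dichlorophenyl to 3-(trifluoromethyl)phenyl: notes on compound 3

The compounds below may be only part of what the source reports. "The series", "measured", "known", "first", "only" and "open" are said of these compounds alone.

Of the compounds shown here, three have been measured so far. In a functional assay on A375P cells (Homo sapiens) for inhibition, read by MTT assay, with a stated time of 24 h (a higher number here means a weaker inhibitor of growth, a lower number a stronger inhibitor of growth), compound 1 `O=C1CC(c2ccc(NC(=O)Nc3ccc(Cl)c(C(F)(F)F)c3)cc2)=Nc2cn[nH]c2N1` gives > 30000 nM, which is a limit of the assay and not a number. Compound 2 `O=C1CC(c2cccc(NC(=O)Nc3ccc(Cl)cc3)c2)=Nc2cn[nH]c2N1` gives > 30000 nM, which is again a limit. Going by the values given here, compound 3 `COc1ccc(Cn2ncc3c2NC(=O)CC(c2cccc(NC(=O)Nc4cc(Cl)cc(Cl)c4)c2)=N3)cc1` gives 780 nM, the only actual number in the set, so it is the sole numerical reference point for what follows.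

The next compound to be tested in this assay is compound 4 `COc1ccc(Cn2ncc3c2NC(=O)CC(c2cccc(NC(=O)Nc4cccc(C(F)(F)F)c4)c2)=N3)cc1`. It has 3-(trifluoromethyl)phenyl in place of 3,5-dichlorophenyl on an amide-type nitrogen. The remainder of the structure is the same as in compound 3.

Among the compounds with values here, no measured pair isolates this exchange, so the expectation rests on a single anchor and carries a wide range. Taking compound 3 at 780 nM as the starting point, a modest loss of growth inhibition is expected, of a size that may only just clear the usual scatter. The estimated step is a 1.7-fold higher number from compound 3 to compound 4 (0.22 log units; within the scatter). For compound 4 the expected value is 1300 nM, with an estimated range of 350 nM to 5500 nM.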

Compound 4, concentration for 50% growth inhibition: 250 nM
Compound 4: the middle estimate sits 5.2-fold (0.72 log units) above what was measured, outside the stated range (below it).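

In this assay, going by these compounds alone, the exchange of 3,5-dichlorophenyl for 3-(trifluoromethyl)phenyl on an amide-type nitrogen gives a 3.1-fold lower number from compound 3 to compound 4 (0.49 log units; beyond the scatter), the first step that can be read as a number. This position therefore accepts a change of the substituents on the phenyl ring without losing growth inhibition, and in this pair the two chlorines are not needed to reach the level of compound 3. Steps from compound 1 or compound 2 to this pair cannot be read, because both differ from it in more than one place and their entries are limits of the assay and not numbers: the limit of > 30000 nM in this assay, at which 2 of the 4 values shown sit.

One pair cannot tell whether the lower number follows from the trifluoromethyl group itself or from the removal of the second chlorine, and a monochlorophenyl, a methoxyphenyl or a cyclohexyl group on this nitrogen would help to separate those readings. Also open, as far as these compounds go, is whether the step of this exchange holds on the core of compound 2, or in any cell line other than this one.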